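This account rests on a few compounds, and the source may have more. Where it says the series, first, only, none or still open, it means among the compounds named here.

Of the compounds shown here, two have numbers so far. Compound 1 `Cc1ccc(/C=N/NC(=O)COc2cccc3ccccc23)cc1` gives 80.1 ug/mL in an ADME assay on HEL cells (Homo sapiens) for cytotoxicity (on this read-out higher numbers stand for lower toxicity in this test and lower numbers for higher toxicity in this test), the highest of the two numbers. Compound 2 `C/C(=N\NC(=O)COc1cccc2ccccc12)c1ccc(Br)cc1` is the other measured member; in this assay compound 2 gives 15.3 ug/mL, a number beyond the scatter from that of compound 1, so the two are clearly separated on this read-out.

Compound 3 `O=C(COc1cccc2ccccc12)N/N=C/c1cccc(Cl)c1` has not yet been measured. It differs from compound 1 in a single place: 3-chlorophenyl in place of 4-methylphenyl on a carbon with a double bond to nitrogen. Among the measured compounds shown here, no step between measured compounds covers this change, so the size of the effect has to be guessed from the spread of the two numbers at hand.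

The expected step from compound 1 to compound 3 is a 1.8-fold lower number from compound 1 to compound 3 (0.25 log units; within the scatter), a decrease judged to fall beyond the scatter. The estimate for compound 3 in this assay is 45 ug/mL, with a range from 20 ug/mL to 100 ug/mL.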

Compound 3, half-maximal cytotoxic concentration: 58.6 ug/mL
For compound 3 the middle estimate is 1.3-fold (0.11 log units) below the measured one; the measured number falls inside the stated range.
By their numbers in this assay, from the lowest: compound 2; then compounds 3 and 1 (each within the scatter of the next).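

In this assay, 3-chlorophenyl in place of 4-methylphenyl on a carbon with a double bond to nitrogen gives a 1.4-fold lower number from compound 1 to compound 3 (0.14 log units; within the scatter), so this single exchange on the shared core does not separate the two compounds on this read-out. The exchange alters both the substituent and its ring position at once, so this one step cannot assign any contribution to either alteration. Nothing available bears on the reason for this result.

Compound 2 differs from compound 1 in more than one place, which leaves the source of its separate number in this assay unresolved. The compounds shown also leave open how an amine or a carboxylic acid on the phenyl ring at this place would read in this assay.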